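The source may hold more compounds than are shown below. What is called first, only, known or untested is meant among the compounds shown, and "the series" means these compounds.

Among the measured compounds shown here, in a physicochemical assay for solubility, read by turbidimetry, measured as kinetic solubility, at pH 7.4 (a lower number here means a less soluble compound, a higher number a more soluble compound), compound 2 (`Cc1cccc(N2C(=O)CSC2c2cccc(C(=O)NCCCCc3ccccc3)c2)c1`) gives (10000 nM), the lowest of the three numbers so far. Compound 1 (`COc1ccc(F)cc1N1C(=O)CSC1c1cccc(C(=O)NCCCCn2cccn2)c1`) gives (50000 nM) and compound 3 (`Cc1ccnc(N2C(=O)CSC2c2cccc(C(=O)NCCCCn3cccn3)c2)c1`) gives (50000 nM). Compound 4 (`CC(F)(F)c1cccc(N2C(=O)CSC2c2cccc(C(=O)NCCCCc3ccccc3)c2)c1`) follows from compound 2 by one change, 1,1-difluoroethyl in place of methyl on an aromatic carbon. For the measured compounds named here, only one measured step bears on it, and only loosely (no change at the digits printed from compound 1 to compound 3 (within the scatter)). That step stayed within the scatter, but it exchanges a different group at a different place, so no measurement tests this change directly. A modest downward move in this assay is expected, close to the size of the scatter (a 2.0-fold lower number from compound 2 to compound 4 (0.30 log units; within the scatter)). Compound 4 is estimated at (5000 nM), with an expected range from (1500 nM) to (14000 nM).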

Compound 4, solubility: 2000 nM
Beside the measured number, compound 4's estimate is 2.5-fold (0.40 log units) above it, and the stated range covers the measured number.
By their numbers in this assay, from the lowest: compound 4; then compound 2; then compounds 1 and 3 (each within the scatter of the next).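

In this assay, putting 1,1-difluoroethyl in place of methyl on this aromatic carbon gives a 5.0-fold lower number from compound 2 to compound 4 (0.70 log units; beyond the scatter), so this position responds to the change by more than the usual scatter. Among the compounds shown here, the only earlier step, no change at the digits printed from compound 1 to compound 3 (within the scatter), exchanged a different group at a different place and showed no such move. Nothing measured here gives a cause for this drop.

From the compounds shown here alone, whether an ethyl or a trifluoromethyl group at this place would land nearer compound 2 or compound 4 stays open. So does the effect of an amine or a carboxylic acid there.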